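The source may hold more compounds than are shown below. What is called first, only, known or untested is meant among the compounds shown, and "the series" means these compounds.

Among the compounds with values here, compound 3 `CC/C=C/CC(=O)O[C@H](CC=C(C)C)C1=CC(=O)c2c(O)ccc(O)c2C1=O` is one of the compounds measured so far in an assay on HeLa cells for inhibition of DNA topoisomerase 1 (Homo sapiens) (a lower number here means a stronger inhibitor, a higher number a weaker inhibitor), where compound 3 gives 153000 nM. Compound 2 `CCC/C=C/C(=O)O[C@H](CC=C(C)C)C1=CC(=O)c2c(O)ccc(O)c2C1=O` gives 153000 nM in this assay, and no change at the digits printed from compound 2 to compound 3 (within the scatter). Compound 1 `CC(C)=CC[C@@H](OC(=O)CCl)C1=CC(=O)c2c(O)ccc(O)c2C1=O` gives 137000 nM, and a 1.1-fold higher number from compound 1 to compound 3 (0.05 log units; within the scatter). So compound 3 shares with compound 2 the highest numbers of the set, and all three values sit within the scatter of one another.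

Compound 4 `C/C=C/C=C/C(=O)O[C@H](CC=C(C)C)C1=CC(=O)c2c(O)ccc(O)c2C1=O` is not yet measured. It differs from compound 3 in one place: penta-1,3-dien-1-yl in place of pent-2-en-1-yl on a carbonyl carbon. Within the data shown here, the steps that bear on this change all alter the same ester group of the shared core. a 1.1-fold higher number from compound 1 to compound 2 (0.05 log units; within the scatter), a 1.1-fold higher number from compound 1 to compound 3 (0.05 log units; within the scatter) and no change at the digits printed from compound 2 to compound 3 (within the scatter), each within the scatter. Since every change at this group so far, including the move of the double bond in compound 2 versus compound 3 (no change at the digits printed from compound 2 to compound 3 (within the scatter)), left this assay unchanged, compound 4 is expected to show no step beyond the scatter: a 1.0-fold lower number from compound 3 to compound 4 (0.01 log units; within the scatter). Compound 4 is estimated at 150000 nM, with a range from 75000 nM to 300000 nM.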

Compound 4, half-maximal inhibitory concentration: 130000 nM
The estimate for compound 4 lay 1.2-fold (0.06 log units) above the measured number; the range from low to high includes it.
By their numbers in this assay, from the lowest: compounds 4, 1, 2 and 3 (each within the scatter of the next).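

In this assay, a second double bond in the group on this carbonyl carbon, with penta-1,3-dien-1-yl in place of pent-2-en-1-yl, gives a 1.2-fold lower number from compound 3 to compound 4 (0.07 log units; within the scatter), and prop-1-en-1-yl in place of propyl gives a 1.2-fold lower number from compound 2 to compound 4 (0.07 log units; within the scatter). Even the change from chloromethyl to penta-1,3-dien-1-yl gives only a 1.1-fold lower number from compound 1 to compound 4 (0.02 log units; within the scatter), so adding a double bond at this position does not separate compound 4 from the other three compounds, and all four remain within the scatter. Nothing available explains this lack of separation.

The compounds shown leave open whether any group at this position can move the number beyond the scatter, such as an amine, a carboxylic acid, a phenyl ring or a longer chain. They also leave open whether an amide in place of the ester would do so.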